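Methylsulfanyl removal on the open-chain hydrazone

The compounds below may be only part of what the source reports. "The series", "measured", "known", "first", "only" and "open" are said of these compounds alone.

Compound 1 `COc1ccc2ccc(=O)oc2c1C1=NN(C(N)=O)C(c2ccc(SC)cc2)C1` and compound 2 `COc1ccc2ccc(=O)oc2c1C(/C=C/c1ccc(SC)cc1)=N/NC(N)=O` share the coumarin-bearing semicarbazone motif; in a functional assay on HepG2 cells (Homo sapiens) for cytotoxicity, read by MTT assay, with a stated time of 72 h (on this read-out higher numbers stand for weaker inhibition and lower numbers for stronger inhibition), compound 1 gives 18 nM, while compound 2 gives 99 nM, the higher of the two numbers. Compound 3 `COc1ccc2ccc(=O)oc2c1C(/C=C/c1ccccc1)=N/NC(N)=O` differs from compound 2 by hydrogen in place of methylsulfanyl on an aromatic carbon. Among the measured compounds shown here, no measured pair shows this change, so the step is expected to be small, a modest weakening at most, possibly not beyond the scatter. Compound 3 is estimated at 200 nM, between 70 nM and 600 nM, which would mean a step of a 2.0-fold higher number from compound 2 to compound 3 (0.31 log units; beyond the scatter).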

Compound 3, half-maximal inhibitory concentration: 82 nM
Estimate against measurement, compound 3: 2.4-fold (0.39 log units) above; low and high end bracket the measured number.
By their numbers in this assay, from the lowest: compound 1; then compounds 3 and 2 (each within the scatter of the next).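

In this assay, the change from 4-(methylsulfanyl)phenyl to phenyl gives a 1.2-fold lower number from compound 2 to compound 3 (0.08 log units; within the scatter) and so stays within the scatter. On this open-chain compound, the methylsulfanyl group is therefore not required for a number in this range, and the unsubstituted phenyl serves as well.

Still open, on these data alone, are whether the same change would be as small on compound 1, and whether an amine or a carboxylic acid in place of methylsulfanyl would move the number. No supporting data bear on why this change makes so little difference.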